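This account rests on a few compounds, and the source may have more. Where it says the series, first, only, none or still open, it means among the compounds named here.

Three compounds share one core and differ only in the group attached to a nitrogen on an aromatic ring. Compound 1 `COc1cc2c(Nc3ccc(Cl)cc3)ncnc2c(OC)c1OC` carries a 4-chlorophenyl there; in a functional assay on BGC-823 cells (Homo sapiens) for inhibition, read by MTT assay, with a stated time of 72 h (a lower number here means a stronger inhibitor, a higher number a weaker inhibitor), compound 1 gives 34400 nM. Compound 2 `COc1cc2c(Nc3cccc(Cl)c3)ncnc2c(OC)c1OC` carries a 3-chlorophenyl instead, and in this assay compound 2 gives 19000 nM. Compound 3 `COc1cc2c(Nc3ccc(O)cc3)ncnc2c(OC)c1OC` carries a 4-hydroxyphenyl, and in this assay compound 3 gives 35400 nM. On these three numbers compound 1 stands second highest, yet every gap is small: a 1.8-fold lower number from compound 1 to compound 2 (0.26 log units; within the scatter), a 1.0-fold higher number from compound 1 to compound 3 (0.01 log units; within the scatter) and a 1.9-fold higher number from compound 2 to compound 3 (0.27 log units; within the scatter) all fall inside the usual scatter, so no ordering among compounds 1, 2 and 3 can be claimed.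

Compound 4 `COc1cc2c(N[C@@H](C)c3ccccc3)ncnc2c(OC)c1OC` has not yet been measured. It differs from compound 1 in one place: 1-phenylethyl in place of 4-chlorophenyl on a nitrogen on an aromatic ring. The three measured steps all concern changes of the group on this same nitrogen, and none of them moved the number beyond the scatter. None swaps an aromatic ring for a 1-phenylethyl group, so nothing in these data speaks directly to that change, and the expectation rests only on the flatness seen so far.

On that basis compound 4 is expected to give 30000 nM, with a likely range from 10000 nM to 90000 nM, a step of a 1.1-fold lower number from compound 1 to compound 4 (0.06 log units; within the scatter) that is expected to stay within the scatter.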

Compound 4, half-maximal inhibitory concentration: 11900 nM
Compound 4: the middle estimate sits 2.5-fold (0.40 log units) above what was measured; measured number inside the range.
By their numbers in this assay, from the lowest: compounds 4, 2, 1 and 3 (each within the scatter of the next, the first and the last beyond it).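

In this assay this nitrogen had so far shown no change beyond the scatter, and 1-phenylethyl, which brings one defined stereocentre, now gives the first such changes: a 2.9-fold lower number from compound 1 to compound 4 (0.46 log units; beyond the scatter) and a 3.0-fold lower number from compound 3 to compound 4 (0.47 log units; beyond the scatter) are both modest but real. The same replacement starting from the 3-chlorophenyl of compound 2 gives a 1.6-fold lower number from compound 2 to compound 4 (0.20 log units; within the scatter) and stays within the scatter, so compound 4 cannot be separated from compound 2, and the position responds only against two of the three aromatic groups. Nothing measured here explains why the number moved.

The compounds shown do not separate the possible sources of this step, since 1-phenylethyl differs from the earlier groups both in its extra carbon between the nitrogen and the ring and in its stereocentre, so a plain benzyl group or the opposite mirror form of compound 4 would be needed to tell these apart. They also leave open whether a group with no aromatic ring at all, such as a cyclohexyl ring or a longer carbon chain, would be tolerated on this nitrogen.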